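A few compounds are considered here, and "the series" means these few. Any claim that something is new, unique, unknown or untested is made for them only; others in the source may bear on it.

Measured so far in a functional assay on NCI-H1975 cells (Homo sapiens) for cytotoxicity, read by CCK-8 assay, with a stated time of 72 h; a higher number here means a weaker inhibitor, a lower number a stronger inhibitor: compound 1 `C=CCn1c(=O)/c(=C\c2cccc(F)c2)[nH]c(=O)/c1=C\c1ccccc1OC` gives 25600 nM; compound 2 `C=CCn1c(=O)/c(=C\c2ccccc2Cl)[nH]c(=O)/c1=C\c1ccccc1OC` gives 9200 nM; compound 3 `C=CCn1c(=O)/c(=C\c2cccc(Br)c2)[nH]c(=O)/c1=C\c1ccccc1OC` is reported as "not active" (no number reported), with no number attached.

Compound 3 therefore stands outside the measured numbers: in this assay it is weaker than compound 1 and compound 2 so far as can be said, but how far is not known. The change to compound 4 `C=CCn1c(=O)/c(=C\c2cccc(C)c2)[nH]c(=O)/c1=C\c1ccccc1OC` is methyl in place of bromo on an aromatic carbon. Among the compounds with values here, no measured step matches this exchange. Within the data shown here, the only step, a 2.8-fold lower number from compound 1 to compound 2 (0.44 log units; beyond the scatter), changes both the halogen and its position at once and bears on it only loosely; the values of compound 1 and compound 3 together show that substituents at this position have so far given weak or no inhibition. A weak result is expected for compound 4, estimated at 30000 nM with a range of 8000 nM to 100000 nM, and a fair chance that again no number is obtained.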

Compound 4, half-maximal inhibitory concentration: 32800 nM
Estimate against measurement, compound 4: 1.1-fold (0.04 log units) below; low and high end bracket the measured number.
By their numbers in this assay, from the lowest: compound 2; then compounds 1 and 4 (each within the scatter of the next).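

With methyl in place of fluoro, a 1.3-fold higher number from compound 1 to compound 4 (0.11 log units; within the scatter) in this assay, so these two groups are not told apart at this ring carbon. The 3-methylphenyl group stays apart from the 2-chlorophenyl group, with a 3.6-fold higher number from compound 2 to compound 4 (0.55 log units; beyond the scatter). Compound 3 has no number, so bromo to methyl cannot be read as a step, and no evidence at hand accounts for these results. From the compounds shown here alone, whether an amine or a carboxylic acid at this ring carbon would lower the number remains open. The compounds shown also do not separate the chloro group in compound 2 from its place on the ring.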